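A few compounds are considered here, and "the series" means these few. Any claim that something is new, unique, unknown or untested is made for them only; others in the source may bear on it.

- compound 1 `CC/C=C\[C@H](C)[C@H](OC(N)=O)[C@@H](C)[C@H](O)[C@@H](C)C/C(C)=C\[C@H](C)[C@@H](O)[C@@H](C)/C=C\[C@@H](O)C[C@H](O)[C@H](C)CO`: 1000 nM
- compound 2 `CC/C=C\[C@H](C)[C@H](OC(N)=O)[C@@H](C)[C@H](O)[C@@H](C)C/C(C)=C\[C@H](C)[C@@H](O)[C@@H](C)/C=C\[C@@H](O)C[C@H](O)[C@H](C)C[C@H](C)C(=O)OC`: 1000 nM

In a functional assay on MCF7 cells (Homo sapiens) for antiproliferative activity (on this read-out lower numbers stand for stronger inhibition of growth and higher numbers for weaker inhibition of growth), compound 2 stands at 1000 nM, level with compound 1. For the measured compounds named here, the only measured step, no change at the digits printed from compound 1 to compound 2 (within the scatter), swapped hydroxy for 1-(methoxycarbonyl)ethyl and stayed within the scatter. Compound 3 `CC/C=C\[C@H](C)[C@H](OC(N)=O)[C@@H](C)[C@H](O)[C@@H](C)C/C(C)=C\[C@H](C)[C@@H](O)[C@@H](C)/C=C\[C@@H](O)C[C@@H]1OC(=O)[C@H](C)[C@@H](OC)[C@H]1C` brings a different kind of change: a group of 11 heavy atoms (8 carbon, 3 oxygen; one six-membered non-aromatic ring with 1 hetero atom) in place of a group of 11 heavy atoms (8 carbon, 3 oxygen; no ring), on a saturated chain carbon, two bonds along the chain from a double-bonded chain carbon and an oxygen on a saturated carbon. The measured step involved no ring, so it offers only a weak guide, and the data do not test ring closure. As a judgement from this structural change, an estimated 5.0-fold lower number from compound 2 to compound 3 (0.70 log units; beyond the scatter) is expected, toward stronger inhibition of growth, with much uncertainty. For compound 3 the estimated value is 200 nM, within an expected range of 20 nM to 1500 nM.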

Compound 3, concentration for 50% growth inhibition: 3.8 nM
Beside the measured number, compound 3's estimate is 53-fold (1.72 log units) above it; the whole stated range lies above it.
By their numbers in this assay, from the lowest: compound 3; then compounds 1 and 2 (each within the scatter of the next).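

In this assay there is a 260-fold lower number from compound 2 to compound 3 (2.42 log units; beyond the scatter) and a 260-fold lower number from compound 1 to compound 3 (2.42 log units; beyond the scatter) once the one six-membered non-aromatic ring with 1 hetero atom enters, so this position can respond strongly to its group, although the open-chain change left compounds 1 and 2 level. Compound 2 and compound 3 carry groups of 11 heavy atoms here, so heavy-atom count alone does not set the number. No measurement available explains this difference. The compounds shown leave open whether the ring, its methoxy group or the added defined stereocentre matters most, and whether a carboxylic acid on the open chain would stay level with compound 2.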